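The source may report more compounds than this note shows. Statements on the series, on what has been measured and on what is new or still open speak of the compounds shown alone.

Compound 1, `CCOC(=O)c1cnc(N2CCN(Cc3ccc(F)cc3)CC2)nc1Oc1c(C)cc(-c2ccc(C#N)cc2)cc1C`: > 117000 nM
Compound 2, `CCOC(=O)c1cnc(N2CCN(Cc3ccccc3[N+](=O)[O-])CC2)nc1Oc1c(C)cc(-c2ccc(C#N)cc2)cc1C`: >= 78700 nM

In an ADME assay on MT4 cells (Homo sapiens) for cytotoxicity, read by MTT assay, with a stated time of 4 days (on this read-out lower numbers stand for higher toxicity in this test and higher numbers for lower toxicity in this test), compound 1 gives > 117000 nM, which is a limit of the test and not a measured number. Compound 2 gives >= 78700 nM, again a limit rather than a number. The step that the two limits leave unreadable from compound 1 to compound 2 therefore cannot be sized, because the limit of > 117000 nM in this assay, at which 1 of the 2 values shown sits, and the limit of >= 78700 nM in this assay, at which 1 of the 2 values shown sits, are all that the two readings show. Compound 2 thus stands at a limit, with no number to place it above or below compound 1.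

Compound 3, `CCOC(=O)c1cnc(N2CCN(Cc3cc(F)cc(F)c3)CC2)nc1Oc1c(C)cc(-c2ccc(C#N)cc2)cc1C`, differs from compound 2 by 3,5-difluorophenyl in place of 2-nitrophenyl on a saturated chain carbon bound to an amine nitrogen in a ring. Among the compounds with values here, the only measured step bears on a change at the same place and is itself unreadable, so no step beyond the scatter is expected in this assay, and the expected step that the limit leaves unreadable from compound 2 to compound 3 is taken as none. Compound 3 is therefore estimated at 100000 nM, between 40000 nM and 200000 nM, most likely again reported only as a limit.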

Compound 3, half-maximal cytotoxic concentration: > 125000 nM
Compound 3: no number, only a limit (the forecaster's own chance of this, stated with the estimate: 85%); at least 1.2-fold (0.09 log units) between middle value and limit.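

In this assay compound 3 gives > 125000 nM, a limit and not a measured number. Compound 1 and compound 2 also stand at limits, so neither step to compound 3 can be read. On these data alone, whether 4-fluorophenyl, 2-nitrophenyl and 3,5-difluorophenyl differ at all in this assay stays open.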